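The source may hold more compounds than are shown below. What is called first, only, known or untested is meant among the compounds shown, and "the series" means these compounds.

Measured in a functional assay on HeLa cells (Homo sapiens) for inhibition, read by MTT assay, with a stated time of 48 h; on this read-out lower numbers stand for stronger inhibition and higher numbers for weaker inhibition:
- compound 1 `CS(=O)(=O)Nc1ccc(-n2cc(COc3ccccc3Cl)nn2)cc1Oc1ccccc1`: 38600 nM
- compound 2 `Cc1ccc(OCc2cn(-c3ccc(NS(C)(=O)=O)c(Oc4ccccc4)c3)nn2)cc1`: 15800 nM
- compound 3 `Cc1cc(OCc2cn(-c3ccc(NS(C)(=O)=O)c(Oc4ccccc4)c3)nn2)ccc1Cl`: 7900 nM

In this assay, compound 3 gives 7900 nM and cannot be separated from compound 2, with a 2.0-fold lower number from compound 2 to compound 3 (0.30 log units; within the scatter). It stands clear of compound 1, with a 4.9-fold lower number from compound 1 to compound 3 (0.69 log units; beyond the scatter).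

Compound 4 `CS(=O)(=O)Nc1ccc(-n2cc(COc3ccc4ccccc4c3)nn2)cc1Oc1ccccc1` carries naphthalen-2-yl in place of 4-chloro-3-methylphenyl on an oxygen on a saturated carbon.

The measured changes at this place are modest: a 2.4-fold lower number from compound 1 to compound 2 (0.39 log units; beyond the scatter) and a 4.9-fold lower number from compound 1 to compound 3 (0.69 log units; beyond the scatter). As far as these compounds go, none of them involves naphthalen-2-yl, so direction remains open and no step beyond the scatter is expected. The expected change is a 1.1-fold higher number from compound 3 to compound 4 (0.06 log units; within the scatter). For compound 4 the estimated value is 9000 nM, with an expected range of 3000 nM to 25000 nM.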

Compound 4, half-maximal inhibitory concentration: 12800 nM
The estimate for compound 4 lay 1.4-fold (0.15 log units) below the measured number; low and high end bracket the measured number.
By their numbers in this assay, from the lowest: compounds 3, 4 and 2 (each within the scatter of the next); then compound 1.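

In this assay, naphthalen-2-yl on this oxygen cannot be separated from the two substituted phenyl groups, with a 1.6-fold higher number from compound 3 to compound 4 (0.21 log units; within the scatter) and a 1.2-fold lower number from compound 2 to compound 4 (0.09 log units; within the scatter), both within the scatter. A group with two aromatic rings and no chlorine therefore still stands clear of 2-chlorophenyl, with a 3.0-fold lower number from compound 1 to compound 4 (0.48 log units; beyond the scatter). No evidence is available to explain these numbers.

All four groups here are aromatic rings of carbon with no hydrogen-bond donors or acceptors. As far as these compounds go, how an amine or a carboxylic acid on the ring would read at this place remains open.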